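This account rests on a few compounds, and the source may have more. Where it says the series, first, only, none or still open, it means among the compounds named here.

Measured compounds in a functional assay on MKN-45 cells (Homo sapiens) for cytotoxicity, read by MTT assay, with a stated time of 72 h; on this read-out higher numbers stand for weaker inhibition and lower numbers for stronger inhibition: compound 1 `COc1cc2c(Oc3ccc(NC(=O)c4nnn(-c5ccc(F)cc5)c4C(F)(F)F)cc3F)ccnc2cc1OCCCN1CCCC1` gives 21 nM; compound 2 `COc1cc2c(Oc3ccc(NC(=O)c4nnn(-c5ccc(C)cc5)c4C(F)(F)F)cc3F)ccnc2cc1OCCCN1CCCC1` gives 210 nM; compound 3 `COc1cc2c(Oc3ccc(NC(=O)c4nnn(-c5ccc(F)cc5)c4C(F)(F)F)cc3F)ccnc2cc1OCCCN1CCCCC1` gives 40 nM.

Compound 3 stands second highest of the three numbers in this assay. Its nearest neighbour is reached through a 1.9-fold higher number from compound 1 to compound 3 (0.28 log units; within the scatter), a gap within the scatter, whereas the value of compound 2 lies well beyond the scatter from that of compound 3.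

Compound 4 `COc1cc2c(Oc3ccc(NC(=O)c4nnn(-c5ccc(F)c(F)c5)c4C(F)(F)F)cc3F)ccnc2cc1OCCCN1CCCCC1` differs from compound 3 in one place: fluoro in place of hydrogen on an aromatic carbon, so the 4-fluorophenyl group becomes 3,4-difluorophenyl. Within the data shown here, no measured step adds a fluoro to this ring. The step of a 10-fold higher number from compound 1 to compound 2 (1.00 log units; beyond the scatter) touches the same phenyl group and shows that what sits on it matters, but it swaps fluoro for methyl rather than adding a second fluoro. The step of a 1.9-fold higher number from compound 1 to compound 3 (0.28 log units; within the scatter) concerns the amine at the chain end and does not bear on the phenyl group at all.

Among the measured compounds shown here, with no directly comparable step, the expected size for compound 4 is a 1.1-fold higher number from compound 3 to compound 4 (0.05 log units; within the scatter), a step not beyond the scatter and of unknown direction, the range being widened because a 10-fold higher number from compound 1 to compound 2 (1.00 log units; beyond the scatter) was beyond the scatter. Compound 4 is therefore estimated at 45 nM, with a range from 18 nM to 120 nM.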

Compound 4, half-maximal inhibitory concentration: 90 nM
Compound 4: middle estimate off by 2.0-fold (0.30 log units), on the low side; low and high end bracket the measured number.
By their numbers in this assay, from the lowest: compounds 1 and 3 (each within the scatter of the next); then compound 4; then compound 2.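

In this assay, adding a second fluoro to the 4-fluorophenyl group to give 3,4-difluorophenyl produces a 2.3-fold higher number from compound 3 to compound 4 (0.35 log units; beyond the scatter), so even this one-atom addition, on an aromatic carbon ortho to the existing fluoro, weakens inhibition by more than the scatter. Among these compounds, until now, the only measured change on this phenyl group was methyl in place of fluoro, a 10-fold higher number from compound 1 to compound 2 (1.00 log units; beyond the scatter), and the new step shows that the read-out also responds at a second carbon of the ring while the original fluoro stays in place; both measured changes on this group raise the number, and neither of the two goes against that direction. Nothing measured on these compounds accounts for the shift.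

The compounds shown leave open whether a chloro or methoxy group on the same carbon would give a similar step, or whether this result is particular to fluoro. Also open, on these data alone, is whether the step seen with the piperidin-1-yl chain end carries over when the 3,4-difluorophenyl group is paired with pyrrolidin-1-yl.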